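Monoamine Oxidase B Inhibitors: A Benzyl Methyl Shift Repeated

The source may report more compounds than this note shows. Statements on the series, on what has been measured and on what is new or still open speak of the compounds shown alone.

Measured compounds:
Compound 1 `Cc1cccc(COc2ccc(-c3nn(CCC#N)c(=O)o3)cc2)c1`: 8 nM
Compound 2 `Cc1ccc(COc2ccc(-c3nn(CCC#N)c(=O)o3)cc2)cc1`: 15 nM
Compound 3 `Cc1cccc(COc2ccc(C3=NN(CCC#N)C(=O)CO3)cc2)c1`: 31 nM

All three were tested in an assay for inhibition of Amine oxidase [flavin-containing] B (Rattus norvegicus); a lower number here means a stronger inhibitor, a higher number a weaker inhibitor. Compounds 1 and 2 share one core, while compound 3 is built on a different core; the difference between the two cores is not broken down here. Within the first pair, the change 4-methylphenyl in place of 3-methylphenyl on a saturated chain carbon bound to an oxygen on an aromatic ring gave a 1.9-fold higher number from compound 1 to compound 2 (0.27 log units; within the scatter), so compounds 1 and 2 cannot be told apart with confidence. Compound 3 has the highest number of the three, its step to compound 2 and to compound 1 lying beyond the scatter.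

Compound 4 `Cc1ccc(COc2ccc(C3=NN(CCC#N)C(=O)CO3)cc2)cc1` has not yet been measured. It relates to compound 3 exactly as compound 2 relates to compound 1: the change is 4-methylphenyl in place of 3-methylphenyl on a saturated chain carbon bound to an oxygen on an aromatic ring, at the same place. Because the step from compound 1 to compound 2 was a 1.9-fold higher number from compound 1 to compound 2 (0.27 log units; within the scatter), the same change on the core of compound 3 is expected to give a step of about a 1.9-fold higher number from compound 3 to compound 4 (0.27 log units; within the scatter) in this assay, a shift of similar size but not separable from the scatter. Compound 4 is therefore estimated at 58 nM, with a likely range from 25 nM to 140 nM.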

Compound 4, half-maximal inhibitory concentration: 320 nM
Compound 4: middle estimate off by 5.5-fold (0.74 log units), on the low side; the whole stated range lies below it.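

Swapping 3-methylbenzyl for 4-methylbenzyl gave a 10-fold higher number from compound 3 to compound 4 (1.01 log units; beyond the scatter) in this assay and so weighed far more on this core than on the core of compound 1. The size of the step therefore did not carry over from one core to the other, and the gap between the two steps is real: the same change on two cores in this assay, a 1.9-fold higher number (0.27 log units; within the scatter) from compound 1 to compound 2 and a 10-fold higher number (1.01 log units; beyond the scatter) from compound 3 to compound 4, 5.5-fold (0.74 log units) apart, beyond the scatter of two such steps. Within the data shown here, with a single pair on each core, this shows only that this particular change cannot be assumed to transfer between these two cores; it does not explain the gap or show that other changes would behave the same way.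

The compounds shown leave open whether a chlorine or a methoxy group in place of the methyl would also separate the two cores so sharply. They also leave open how either core would respond if the nitrile chain gave way to a longer chain or a carboxylic acid.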